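Swapping an Amide Aryl Group for a Benzylamino Urea

The source may report more compounds than this note shows. Statements on the series, on what has been measured and on what is new or still open speak of the compounds shown alone.

Two relatives of a shared core have been tested in an assay on CHO cells for displacement of a labelled ligand from adenosine receptor A1 (Homo sapiens), tested at 10 uM; a higher number here means more inhibition at the concentration tested (going by the name of the read-out), a lower number less inhibition. Compound 1, `O=C(Nc1nn(-c2ccccc2)c(=O)c2ccccc12)c1ccc(Cl)cc1`, carries a 4-chlorophenyl group on its carbonyl carbon; in this assay compound 1 gives 26%. Compound 2, `CC(=O)N(C(C)=O)c1nn(-c2ccccc2)c(=O)c2ccccc12`, shares the core but differs at the same side; in this assay compound 2 gives 47%. Going by the values given here, of the two numbers, the one for compound 1 is the lower, and its gap to compound 2 lies beyond the usual scatter of repeated measurements.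

The untested compound 3, `COc1ccccc1CNC(=O)Nc1nn(-c2ccccc2)c(=O)c2ccccc12`, is compound 1 with one change: (2-methoxybenzyl)amino in place of 4-chlorophenyl on a carbonyl carbon. Among the compounds with values here, no pair of measured compounds differs in just this way, so nothing measured here tells how large a step this change brings. With only two measured points, both of modest inhibition, the step is expected to be small, in either direction, and most likely within the scatter: a number 4 percentage points higher from compound 1 to compound 3 (within the scatter) is the estimated step. Compound 3 is therefore expected to give about 30% in this assay, with a plausible range from 8% to 58%.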

Compound 3, a percentage reported as inhibition, at one concentration (the size of the read-out at that concentration, not a potency): 28%
Estimate against measurement, compound 3: 2 percentage points above; measured number inside the range.
By their numbers in this assay, from the lowest: compounds 1 and 3 (each within the scatter of the next); then compound 2.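

The one-place comparison of this set shows that in this assay, putting (2-methoxybenzyl)amino in place of 4-chlorophenyl on a carbonyl carbon gives a number 2 percentage points higher from compound 1 to compound 3 (within the scatter), so the size of this change can now be read directly rather than guessed. The two groups differ considerably: the entering group has more heavy atoms, brings a hydrogen-bond donor and a hydrogen-bond acceptor that 4-chlorophenyl lacks, and has no chlorine, yet this read-out cannot tell the two compounds apart. No supporting measurement offers an explanation for this result.

Each group here carries a six-membered aromatic ring of carbon only, so the compounds shown leave open what happens on this carbonyl carbon when a group without such a ring, such as a simple amine or a carboxylic acid, takes its place. They also leave open whether the methoxy group in (2-methoxybenzyl)amino contributes anything, which a plain benzylamino group would test, and, since the read-out comes from a single concentration, how potency compares across these compounds.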